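Removing a Phenyl Group from a Non-Toxic Series

The compounds below may be only part of what the source reports. "The series", "measured", "known", "first", "only" and "open" are said of these compounds alone.

Three compounds sharing one core were tested in an ADME assay on HepG2 cells (Homo sapiens) for cytotoxicity, read by CellTiter-Glo and ATP content, with a stated time of 72 h; a higher number here means that more compound is needed for the effect, a lower number that less compound is needed. Compound 1 `CN(Cc1cccc(F)c1)C(=O)CCCNC(=O)c1ccc(S(C)(=O)=O)c([N+](=O)[O-])c1` gives > 27000 nM, which is a limit of the measurement rather than a number. Compound 2 `CC1CCN(C(=O)CCNC(=O)c2ccc(S(C)(=O)=O)c([N+](=O)[O-])c2)CC1` gives > 27000 nM, again a limit. Compound 3 `CS(=O)(=O)c1ccc(C(=O)NCCCC(=O)N2CCC(c3ccccc3)CC2)cc1[N+](=O)[O-]` likewise gives > 27000 nM, also a limit. Compound 3 thus stands where the other two stand, at the limit of > 27000 nM in this assay, at which 3 of the 3 values shown sit.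

Compound 4 `CS(=O)(=O)c1ccc(C(=O)NCCCC(=O)N2CCCCC2)cc1[N+](=O)[O-]` differs from compound 3 by one change: hydrogen in place of phenyl on a saturated ring carbon. Within the data shown here, no step between two measured compounds has been reported, so nothing shows how such a change moves the read-out. Because the limit of > 27000 nM in this assay, at which 3 of the 3 values shown sit, holds all three measured values, no shift beyond the usual scatter is expected in either direction. The expected step from compound 3 to compound 4 is a step that the limit leaves unreadable from compound 3 to compound 4. Compound 4 is therefore estimated at about 40000 nM, between 20000 nM and 100000 nM, and most likely reported again only as a limit.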

Compound 4, half-maximal effective concentration: > 27000 nM
Compound 4 was reported as a limit; the forecaster's own chance of this, stated with the estimate: 90%; the middle value is on the limit's open side.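

Compound 4 is again reported only as a limit, so the steps to it from compound 1, compound 2 and compound 3 cannot be read: the limit of > 27000 nM in this assay, at which 4 of the 4 values shown sit. The compounds shown leave open what concentration of any of them would give the half-maximal effect, and so whether the loss of the phenyl changes it at all.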